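Trimming an Amide Substituent on a Kinase Inhibitor

The compounds below may be only part of what the source reports. "The series", "measured", "known", "first", "only" and "open" are said of these compounds alone.

Of the compounds shown here, three sharing one core have been measured in an assay for inhibition of serine/threonine-protein kinase PLK2 (Homo sapiens), read by FRET and Z'-LYTE, with a stated time of 1 h; on this read-out lower numbers stand for stronger inhibition and higher numbers for weaker inhibition. Compound 1 `CCC1C(=O)N(C)c2cnc(-n3ccc4cc(C(=O)NCC(C)C)ccc43)nc2N1c1ccn(C)n1` gives 159 nM, and compound 3 `CCC1C(=O)N(C)c2cnc(Nc3ccc(S(N)(=O)=O)cc3)nc2N1c1ccn(C)n1` gives 121 nM. Compound 2 `CC[C@@H]1C(=O)N(C)c2cnc(-n3ccc4cc(C(=O)NC(C)C)ccc43)nc2N1C1CCCC1` gives 17.4 nM, the lowest number of the three; its gaps to compound 3 and to compound 1 both lie beyond the usual scatter, so compound 2 is the strongest inhibitor among them.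

Compound 4 `CC[C@@H]1C(=O)N(C)c2cnc(-n3ccc4cc(C(=O)NC)ccc43)nc2N1C1CCCC1` differs from compound 2 in one place: methyl in place of isopropyl on an amide-type nitrogen. Going by the values given here, no pair of measured compounds shows this exact change, so the size of the step is uncertain. Because compound 2 gives 17.4 nM and the change only shortens a chain on the amide nitrogen without adding or removing donors or acceptors, the step in this assay is expected to be small, perhaps a modest weakening or none beyond the scatter. Compound 4 is therefore estimated at 30 nM, within a range from 10 nM to 90 nM, a step of a 1.7-fold higher number from compound 2 to compound 4 (0.24 log units; within the scatter).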

Compound 4, half-maximal inhibitory concentration: 8.6 nM
Compound 4: the middle estimate sits 3.5-fold (0.54 log units) above what was measured; measured number below the stated range.
By their numbers in this assay, from the lowest: compound 4; then compound 2; then compounds 3 and 1 (each within the scatter of the next).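

In this assay, going by these compounds alone, placing methyl instead of isopropyl on the amide-type nitrogen gives a 2.0-fold lower number from compound 2 to compound 4 (0.31 log units; beyond the scatter), the first direct reading of a change at this position, as no earlier pair of compounds differed in one place. The step is modest but beyond the usual scatter, so the larger isopropyl is not needed for inhibition here, and the shorter group does slightly better. Nothing available explains why the smaller group gives the lower number.

On these data alone, a single step cannot show whether shrinking this substituent keeps helping or how far a larger one can go, so a plain primary amide, with only hydrogens on the nitrogen, and a longer chain such as n-butyl remain open. As far as these compounds go, it also remains open whether the same change would give a similar step on compounds that differ elsewhere on the shared core.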